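This account rests on a few compounds, and the source may have more. Where it says the series, first, only, none or still open, it means among the compounds named here.

Series notes, antiproliferative work on a shared thiophene-type scaffold bearing a trimethoxyphenyl group and a para-methoxyphenyl group.

Compound 1 `CCOC(=O)c1cc(-c2cc(OC)c(OC)c(OC)c2)c(-c2ccc(OC)cc2)s1` carries an ethyl ester on the core. In a functional assay on SGC-7901 cells (Homo sapiens) for antiproliferative activity, read by MTT assay, with a stated time of 72 h (a higher number here means a weaker inhibitor, a lower number a stronger inhibitor), compound 1 gives 9760 nM. Compound 2 `CCOC(=O)c1cc(-c2cc(OC)c(OC)c(OC)c2)c(-c2ccc(OC)c([N+](=O)[O-])c2)s1` is its nitro analogue; in this assay compound 2 gives 18100 nM. The change between them is nitro in place of hydrogen on an aromatic carbon, and the step it made is a 1.9-fold higher number from compound 1 to compound 2 (0.27 log units; within the scatter), so the two values are not distinguishable here.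

Compound 3 `COc1ccc(-c2cc(C(=O)O)sc2-c2cc(OC)c(OC)c(OC)c2)cc1` has the free acid in place of the ester. The difference between the core of compound 1 and the core of compound 3 is not broken down here. In this assay, among the compounds with values here, compound 3 gives 4220 nM, the lowest of the three numbers so far, and its gaps to compound 1 and to compound 2 are beyond the usual scatter.

Compound 4 `COc1ccc(-c2cc(C(=O)O)sc2-c2cc(OC)c(OC)c(OC)c2)cc1[N+](=O)[O-]` has not yet been measured. It differs from compound 3 by nitro in place of hydrogen on an aromatic carbon, the same change as from compound 1 to compound 2, and at the same kind of place on the ring. On that single precedent, the expectation for this assay is a step of about a 1.8-fold higher number from compound 3 to compound 4 (0.25 log units; within the scatter), small because a 1.9-fold higher number from compound 1 to compound 2 (0.27 log units; within the scatter) was all that the same change produced in the ester pair, and that earlier step stayed within the scatter. Compound 4 is therefore estimated at 7500 nM, with a plausible range from 3500 nM to 16000 nM; the measurement will show whether the acid series follows the ester series.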

Compound 4, half-maximal inhibitory concentration: 21600 nM
Estimate against measurement, compound 4: 2.9-fold (0.46 log units) below; the measured number lies above the stated range.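

In this assay, nitro in place of hydrogen on an aromatic carbon on the acid core gives a 5.1-fold higher number from compound 3 to compound 4 (0.71 log units; beyond the scatter), so on this core the change carries a clear loss in antiproliferative potency. On the ester core the same change gave a 1.9-fold higher number from compound 1 to compound 2 (0.27 log units; within the scatter), which leaves the two ester values indistinguishable, so the size of the step does not transfer from one core to the other: the same change on two cores in this assay, a 1.9-fold higher number (0.27 log units; within the scatter) from compound 1 to compound 2 and a 5.1-fold higher number (0.71 log units; beyond the scatter) from compound 3 to compound 4, 2.8-fold (0.44 log units) apart, beyond the scatter of two such steps. This shows that the effect of the nitro group depends on the core in these two pairs, but two pairs give no reason for the difference and no rule for how the change would behave on any further core.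

The compounds shown leave open whether another group at the same place, ortho to a methoxy group, such as an amine or a fluorine atom, would also give steps of different size on the ester core and the acid core. They also leave open whether the larger step belongs to the carboxylic acid specifically, or whether a primary amide or a longer ester chain on the core would give a step closer to that of the acid pair or of the ester pair.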